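The source may report more compounds than this note shows. Statements on the series, on what has been measured and on what is new or still open speak of the compounds shown alone.

Measured so far:
- compound 1, `CC(C)CC(C#Cc1cccc(C(=O)NCc2ccccc2C(F)(F)F)c1)N(O)C(N)=O`, in an assay for inhibition of Polyunsaturated fatty acid 5-lipoxygenase (Homo sapiens), read by HPLC, with stated times of 15 min and 10 min (a higher number here means a weaker inhibitor, a lower number a stronger inhibitor), gives 600 nM
- compound 2, `CC(C#Cc1cccc(C(=O)NCc2ccccc2OC(F)(F)F)c1)N(O)C(N)=O`, in this assay gives 1000 nM
- compound 3, `NC(=O)N(O)CC#Cc1cccc(C(=O)NCc2ccccc2C(F)(F)F)c1`, in this assay gives 4000 nM

Compound 3 has the highest number of the three in this assay; the nearest is compound 2, the furthest compound 1, and both gaps lie beyond the scatter.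

The next compound, compound 4, `CC(C#Cc1cccc(C(=O)NCc2ccccc2C(F)(F)F)c1)N(O)C(N)=O`, differs from compound 3 in one place: methyl in place of hydrogen on a saturated chain carbon bound to an amide-type nitrogen and a triple-bonded carbon. For the measured compounds named here, the one measured step at this same place is a 6.7-fold higher number from compound 1 to compound 3 (0.82 log units; beyond the scatter), which runs the other way, from a larger chain to hydrogen, and was beyond the scatter. Compound 2 also carries a methyl at that place but differs elsewhere as well, so its value only shows where such a compound can sit. A methyl is smaller than isobutyl, so the step back is expected to be smaller than that from compound 1 to compound 3 and to point toward a lower number. The expected step is a 3.3-fold lower number from compound 3 to compound 4 (0.52 log units; beyond the scatter). Compound 4 is therefore estimated at 1200 nM, within 450 nM to 3000 nM.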

Compound 4, half-maximal inhibitory concentration: 700 nM
Beside the measured number, compound 4's estimate is 1.7-fold (0.23 log units) above it; the range from low to high includes it.
By their numbers in this assay, from the lowest: compounds 1, 4 and 2 (each within the scatter of the next); then compound 3.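

Methyl in place of hydrogen on the saturated chain carbon gives a 5.7-fold lower number from compound 3 to compound 4 (0.76 log units; beyond the scatter) in this assay and so accounts for a step of similar reach to the one seen with isobutyl, since a 1.2-fold higher number from compound 1 to compound 4 (0.07 log units; within the scatter) leaves the larger group with no readable edge over methyl. On the aromatic carbon, trifluoromethyl in place of trifluoromethoxy gives a 1.4-fold lower number from compound 2 to compound 4 (0.15 log units; within the scatter) and does not separate the two groups while methyl sits on the chain. No measurement on hand bears on why methyl has this effect.

Open, as far as these compounds go, is whether ethyl, a cyclopropyl ring or a carboxylic acid at the same chain carbon would stay level with methyl and isobutyl or depart from them. Also open, from the compounds shown here alone, is whether the two mirror-image forms at that carbon differ.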